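This account rests on a few compounds, and the source may have more. Where it says the series, first, only, none or still open, it means among the compounds named here.

Measured compounds:
- Compound 1 `COc1ccc(CNc2nc([SeH])nc3ccccc23)cc1`: in a functional assay on CCRF-CEM cells (Homo sapiens) for cytotoxicity, read by MTT assay, with a stated time of 72 h (a higher number here means that more compound is tolerated, a lower number that less compound is tolerated), compound 1 gives > 100000 nM, which is a limit of the assay and not a number.
- Compound 2 `Sc1nc(NCc2ccccc2)c2ccccc2n1`: in this assay compound 2 gives > 100000 nM, again a limit of the assay rather than a number.

Compound 2 therefore stands on a limit only; no measured number places it within the range of this assay. Within the data shown here, both values shown sit at the same limit, (the limit of > 100000 nM in this assay, at which 2 of the 2 values shown sit), so no step between measured compounds can be read from these data.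

Compound 3 `[SeH]c1nc(NCc2ccccc2)c2ccccc2n1` differs from compound 2 by one selenium atom in place of one sulfur atom, on an aromatic carbon. Compound 1 also carries the selenium group, and in this assay compound 1 gives > 100000 nM, a limit.

With both measured values at the limit, the step from compound 2 to compound 3 is expected to be none beyond the scatter, a step that the limit leaves unreadable from compound 2 to compound 3. Compound 3 is estimated at 150000 nM, within 50000 nM to 500000 nM, most likely reported again only as a limit.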

Compound 3, concentration lethal to 50% of the cells: > 100000 nM
Compound 3: a limit, no number; the forecaster's own chance of this, stated with the estimate: 85%; the middle value is on the limit's open side.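

No step can be read from compound 2 to compound 3 or from compound 1 to compound 3, because all three compounds sit at one limit: the limit of > 100000 nM in this assay, at which 3 of the 3 values shown sit.

The compounds shown leave open whether selenium in place of sulfur or hydrogen in place of methoxy has any effect in this assay.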